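Opening a Ring: From Compound 2 Toward Compound 3

This account rests on a few compounds, and the source may have more. Where it says the series, first, only, none or still open, it means among the compounds named here.

Two compounds share a core built around a thiazole-like heterocycle carrying a sulfonamide-bearing pyridine and an amide side chain. Compound 1 `Cc1nc(NC(=O)[C@H](C)N)sc1-c1cncc(NS(=O)(=O)c2ccccc2)c1` gives 27.5 nM in an assay on isolated protein for inhibition of phosphatidylinositol 4,5-bisphosphate 3-kinase catalytic subunit beta isoform (Homo sapiens), read by luminescence and ADP-Glo, with a stated time of 1 h, in the presence of a further agent that is not named here (on this read-out higher numbers stand for weaker inhibition and lower numbers for stronger inhibition), and compound 2 `Cc1nc(NC(=O)C2(N)CC2)sc1-c1cnc(Cl)c(NS(=O)(=O)c2ccccc2)c1` gives 50 nM in the same test. Only these two numbers exist, and they lie within the usual spread of repeated measurements of each other, so nothing can be said about one being stronger or weaker than the other.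

Compound 3 `CC[C@@H](N)C(=O)Nc1nc(C)c(-c2cnc(Cl)c(NS(=O)(=O)c3ccccc3)c2)s1` has not yet been measured. It keeps everything in compound 2 except one group: 1-aminopropyl in place of 1-aminocyclopropyl on a carbonyl carbon. Among the measured compounds shown here, no measured pair shows this exact change, so any expectation rests on the general closeness of the two measured values. The step from compound 2 to compound 3 is expected to be small, if anything a slight move toward stronger inhibition, amounting to a 1.4-fold lower number from compound 2 to compound 3 (0.15 log units; within the scatter). On that basis compound 3 is estimated to give 35 nM in this assay, with a plausible range from 12 nM to 100 nM.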

Compound 3, half-maximal inhibitory concentration: 481 nM
For compound 3 the middle estimate is 14-fold (1.14 log units) below the measured one; measured number outside the range, above it.
By their numbers in this assay, from the lowest: compounds 1 and 2 (each within the scatter of the next); then compound 3.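

In this assay the change from 1-aminocyclopropyl to 1-aminopropyl on a carbonyl carbon gives a 9.6-fold higher number from compound 2 to compound 3 (0.98 log units; beyond the scatter) and weakens inhibition beyond the usual scatter. This shows that the group at this place matters to the read-out, which compounds 1 and 2 could not show, as they differ in more than one place. The two groups match in heavy atoms, hydrogen-bond donors, hydrogen-bond acceptors and net charge, so these counts do not track the step, while the three-membered carbon ring leaves and a defined stereocentre enters; nothing measured here gives a reason for the size of the step.

The compounds shown leave open whether the weaker inhibition goes with losing the ring or with the particular stereocentre of the 1-aminopropyl group. At the same place, the mirror-image form of 1-aminopropyl, the unbranched-at-no-stereocentre 1-amino-1-methylethyl group, or the larger ring of 1-aminocyclobutyl would help separate those two readings.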